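The compounds below may be only part of what the source reports. "The series", "measured", "known", "first", "only" and "open" are said of these compounds alone.

Values in a functional assay on cells (Neutrophil, Homo sapiens) for inhibition, read by transwell migration; on this read-out lower numbers stand for stronger inhibition and higher numbers for weaker inhibition:
- compound 1 `COC(=O)c1c(NCCN(C)C)n(-c2ccccc2)c(=S)n(-c2ccccc2)c1=O` (3.32 nM)
- compound 2 `CC(=O)c1c(NCCN(C)C)n(-c2ccccc2)c(=S)n(-c2ccccc2)c1=O` (6.86 nM)
- compound 3 `CCOC(=O)c1c(NCCN(C)C)n(-c2ccccc2)c(=S)n(-c2ccccc2)c1=O` (0.1 nM)

Compound 3 has the lowest number of the three. The gaps leading to it are a 33-fold lower number from compound 1 to compound 3 (1.52 log units; beyond the scatter) and a 69-fold lower number from compound 2 to compound 3 (1.84 log units; beyond the scatter). Compound 4 `CC(C)OC(=O)c1c(NCCN(C)C)n(-c2ccccc2)c(=S)n(-c2ccccc2)c1=O` changes ethoxycarbonyl to isopropoxycarbonyl: methyl in place of hydrogen on a saturated chain carbon bound to an oxygen next to a carbonyl group and a saturated chain carbon. Going by the values given here, the closest precedent is a 33-fold lower number from compound 1 to compound 3 (1.52 log units; beyond the scatter), also methyl in place of hydrogen on a saturated chain carbon bound to an oxygen next to a carbonyl group. That is a single example, and no branched ester has been measured, so a repeat is not assumed. The other change, a 2.1-fold higher number from compound 1 to compound 2 (0.32 log units; beyond the scatter), is of a different kind and gives little guidance. A modest rise in this assay is expected, with the direction uncertain: the estimated step is a 4.0-fold higher number from compound 3 to compound 4 (0.60 log units; beyond the scatter). The estimate for compound 4 is 0.4 nM, with a range from 0.04 nM to 4 nM.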

Compound 4, half-maximal inhibitory concentration: 0.18 nM
The estimate for compound 4 lay 2.2-fold (0.35 log units) above the measured number; the measured number falls inside the stated range.
By their numbers in this assay, from the lowest: compounds 3 and 4 (each within the scatter of the next); then compound 1; then compound 2.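

In this assay, adding a methyl to this saturated chain carbon does not repeat the large step seen earlier for the same kind of addition (a 1.8-fold higher number from compound 3 to compound 4 (0.26 log units; within the scatter)). Isopropoxycarbonyl, the first branched ester here, keeps a large margin over the methyl ester (an 18-fold lower number from compound 1 to compound 4 (1.27 log units; beyond the scatter)) and over the acetyl group (a 38-fold lower number from compound 2 to compound 4 (1.58 log units; beyond the scatter)). No evidence on hand bears on this result.

Still open, on these data alone, is whether a tert-butyl ester or a longer chain such as butyl would hold these low numbers. An amide or a carboxylic acid in place of the ester is equally unresolved.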